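The source may report more compounds than this note shows. Statements on the series, on what has been measured and on what is new or still open speak of the compounds shown alone.

Measured in a functional assay on RPMI-8226 cells (Homo sapiens) for inhibition, read by sulforhodamine B assay, with a stated time of 48 h; on this read-out higher numbers stand for lower toxicity in this test and lower numbers for higher toxicity in this test:
- compound 1 `COc1ccc(-c2cc(/C=C/C(=O)c3ccc(N)cc3)[nH]n2)cc1` gives 29400 nM.
- compound 2 `COc1ccc(-c2cc(/C=C/C(=O)c3ccc(N)cc3)[nH]n2)cc1OC` gives only a limit, > 100000 nM.
- compound 3 `COc1cc(C(=O)/C=C/c2cc(-c3cc(OC)c(OC)c(OC)c3)n[nH]2)cc(OC)c1OC` gives only a limit, > 100000 nM.

Among the measured compounds shown here, the one measured step, an at least 3.4-fold lower number from compound 2 to compound 1 (0.53 log units; beyond the scatter), is the change (hydrogen in place of methoxy on an aromatic carbon). Compound 4 `COc1ccc(-c2cc(/C=C/C(=O)c3cc(OC)c(OC)c(OC)c3)[nH]n2)cc1OC`, not yet measured, arises from compound 3 by hydrogen in place of methoxy on an aromatic carbon; this is the same kind of change, the place here being additionally meta to a methoxy group. How the cores of compound 2 and compound 3 differ is not broken down here. Note (the limit of > 100000 nM in this assay, at which 2 of the 3 values shown sit). Compound 3 stands at a limit, so the step to compound 4 is open at its start. The step expected from compound 3 to compound 4, an at least 1.6-fold lower number from compound 3 to compound 4 (0.22 log units; that floor lies within the scatter), rests on an at least 3.4-fold lower number from compound 2 to compound 1 (0.53 log units; beyond the scatter). Compound 4 is estimated at 60000 nM, from 20000 nM to 150000 nM, with a real chance that only a limit is reported.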

Compound 4, concentration lethal to 50% of the cells: > 100000 nM
Compound 4: only a limit was reported; the forecaster's own chance of this, stated with the estimate: 50%; middle value at least 1.6-fold (0.22 log units) away from the limit.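

No step can be read from compound 3 to compound 4, since both stand at a limit in this assay: the limit of > 100000 nM in this assay, at which 3 of the 4 values shown sit.

Still open, from the compounds shown here alone, is whether hydrogen in place of methoxy changes the read-out at all on this core.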